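The source may hold more compounds than are shown below. What is called first, only, known or untested is meant among the compounds shown, and "the series" means these compounds.

Working notes on the series in a functional assay on cells (Mus musculus) for antiproliferative activity, read by sulforhodamine B assay, with a stated time of 5 days; on this read-out lower numbers stand for stronger inhibition and higher numbers for weaker inhibition.

Compound 1 `COc1ccc(C2(c3cc(C(C)(C)C)ccc3O)C(=O)Nc3ccccc32)cc1` gives 15700 nM in this assay. Compound 3 `CC(C)(C)c1ccc(O)c(C2(c3ccc(O)cc3)C(=O)Nc3ccccc32)c1` differs from it by hydrogen in place of methyl on an oxygen on an aromatic ring; compound 3 gives 17300 nM in this assay, and the measured size of this change on the core of compound 1 is a 1.1-fold higher number from compound 1 to compound 3 (0.04 log units; within the scatter). Compound 2 `COc1ccc(C2(c3cc(C(C)(C)C)ccc3O)C(=O)Nc3c2ccc(F)c3F)cc1` carries a different core; the difference between the two cores is not broken down here. Compound 2 gives 12300 nM in this assay. Its value and those of compound 1 and compound 3 lie close together, so no ordering among the three is drawn from them.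

Compound 4 `CC(C)(C)c1ccc(O)c(C2(c3ccc(O)cc3)C(=O)Nc3c2ccc(F)c3F)c1` is not yet measured. It stands to compound 2 as compound 3 stands to compound 1: the change hydrogen in place of methyl on an oxygen on an aromatic ring is the same change as from compound 1 to compound 3, at the same place, with an aromatic carbon as the other neighbour of the oxygen in both cases. The change occurs twice among these compounds, once with a measurement.

The expectation for compound 4 rests on that single precedent, because a 1.1-fold higher number from compound 1 to compound 3 (0.04 log units; within the scatter) shows the change leaving the number essentially where it was on the core of compound 1. The expected step is accordingly small, a 1.1-fold higher number from compound 2 to compound 4 (0.04 log units; within the scatter). The estimate for compound 4 in this assay is 13500 nM, with a span from 7000 nM to 27000 nM; one precedent leaves the range wide.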

Compound 4, half-maximal inhibitory concentration: 15300 nM
Estimate against measurement, compound 4: 1.1-fold (0.05 log units) below, and the stated range covers the measured number.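

On the core of compound 2, replacing methoxy with hydroxy in the 4-methoxyphenyl group gives a 1.2-fold higher number from compound 2 to compound 4 (0.09 log units; within the scatter) in this assay. Set beside the earlier step, the change behaves alike on the two cores: the same change on two cores in this assay, a 1.1-fold higher number (0.04 log units; within the scatter) from compound 1 to compound 3 and a 1.2-fold higher number (0.09 log units; within the scatter) from compound 2 to compound 4, 1.1-fold (0.05 log units) apart, within the scatter of two such steps This shows that, on these two cores and in this one read-out, the change can be carried from one core to the other with no visible shift in the number, but since both steps lie within the scatter, the agreement is only between two steps too small to read, and it does not show how the change would behave on a core where it had a larger effect, or on any core beyond these two.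

The compounds shown leave open what happens when the oxygen of the 4-hydroxyphenyl group carries something other than hydrogen or methyl, such as a longer chain or a chain ending in a carboxylic acid, or when an amine takes the place of that oxygen. They also leave open whether any such replacement would move the number in this assay beyond the scatter.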